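A few compounds are considered here, and "the series" means these few. Any claim that something is new, unique, unknown or untested is made for them only; others in the source may bear on it.

Working notes on the aroyl-aminothiophene series, assessed in a functional assay on L1210 cells (Mus musculus) for antiproliferative activity; on this read-out higher numbers stand for weaker inhibition and lower numbers for stronger inhibition.

Compound 2 `COc1cc(C(=O)c2sc(-c3cccc([N+](=O)[O-])c3)cc2N)cc(OC)c1OC` gives 11 nM and stands lowest of the three numbers measured. Compound 1 `COc1cc(C(=O)c2sc(-c3ccc(Br)cc3)cc2N)cc(OC)c1OC` gives 100 nM; compound 3 `COc1cc(C(=O)c2sc(-c3ccc(Cl)c(Cl)c3)cc2N)cc(OC)c1OC` gives 260 nM. Both measured steps that touch compound 2 concern the aryl group on the five-membered ring: a 9.1-fold lower number from compound 1 to compound 2 (0.96 log units; beyond the scatter), and a 24-fold higher number from compound 2 to compound 3 (1.37 log units; beyond the scatter). The third step, a 2.6-fold higher number from compound 1 to compound 3 (0.41 log units; beyond the scatter), lies between the two halogenated aryl groups.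

Compound 4 `COc1ccc(-c2cc(N)c(C(=O)c3cc(OC)c(OC)c(OC)c3)s2)cc1` is not yet measured. It differs from compound 2 in this way: 4-methoxyphenyl in place of 3-nitrophenyl on an aromatic carbon. Among the compounds with values here, no measured step covers a methoxy on the pendant phenyl, so the nearest guide is that every departure from 3-nitrophenyl seen so far raised the number in this assay, by modest to large amounts, with compound 1 the closer analogue in size of effect.

The step from compound 2 to compound 4 is therefore expected to raise the number, estimated as a 2.7-fold higher number from compound 2 to compound 4 (0.44 log units; beyond the scatter). Compound 4 is estimated at 30 nM, with a range from 5 nM to 200 nM.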

Compound 4, half-maximal inhibitory concentration: 45 nM
For compound 4 the middle estimate is 1.5-fold (0.18 log units) below the measured one, and the stated range covers the measured number.
By their numbers in this assay, from the lowest: compound 2; then compound 4; then compound 1; then compound 3.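

On the aromatic carbon next to the ring sulfur, the 4-methoxyphenyl group gives a fourth distinct level in this assay: 3-nitrophenyl stays ahead, with a 4.1-fold higher number from compound 2 to compound 4 (0.61 log units; beyond the scatter), while the new group improves on both halogenated aryl groups, with a 2.2-fold lower number from compound 1 to compound 4 (0.35 log units; beyond the scatter) and a 5.8-fold lower number from compound 3 to compound 4 (0.76 log units; beyond the scatter). That step from bromo to methoxy shows that this position separates two 4-substituted phenyl groups, not only groups with different substitution patterns. Nothing at hand accounts for this order.

As far as these compounds go, whether the lead of compound 2 belongs to the nitro group or to where it sits on the phenyl ring remains open, and a 4-nitrophenyl or 3-methoxyphenyl group would separate the two. From the compounds shown here alone, how a 3-aminophenyl or 3-carboxyphenyl group would compare at this position also remains open.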